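Replacing tert-butyl with methoxy on the outer aryl ring

The compounds below may be only part of what the source reports. "The series", "measured", "known", "first", "only" and "open" are said of these compounds alone.

Compound 1 `Clc1ccc(CO/N=C/c2c(-c3ccc(C4CCCCC4)cc3)nc3sccn23)cc1Cl` reaches only a limit in an assay on HepG2 cells for agonist activity at nuclear receptor subfamily 1 group I member 3 (Homo sapiens), read by a luciferase reporter, with a stated time of 23 h (on this read-out lower numbers stand for an effect already at smaller amounts and higher numbers for an effect only at larger amounts of compound), giving > 100000 nM. Going by the values given here, compound 2 `CC(C)(C)c1ccc(-c2nc3sccn3c2/C=N/OCc2ccc(Cl)c(Cl)c2)cc1` gives 2400 nM in this assay and is the single compound with a number; the other two entries carry no single number. Compound 3 `CC1(C)CCC(C)(C)c2cc(-c3nc4sccn4c3/C=N/OCc3ccc(Cl)c(Cl)c3)ccc21` is recorded in this assay as "not active" (no number reported). Among the compounds with values here, the one measured step, tert-butyl in place of cyclohexyl on an aromatic carbon, gives an at least 41-fold lower number from compound 1 to compound 2 (1.61 log units; beyond the scatter); its size rests on the starting point at the limit (the limit of > 100000 nM in this assay, at which 1 of the 3 values shown sits), so only a lower bound of the step is known.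

Compound 4 `COc1ccc(-c2nc3sccn3c2/C=N/OCc2ccc(Cl)c(Cl)c2)cc1` carries the change (methoxy in place of tert-butyl on an aromatic carbon). The step from compound 1 to compound 2 is the only one at this position and shows the number moving strongly with the group on that aromatic carbon; compound 3, with a larger fused group there, carries no number. Moving from tert-butyl to the smaller methoxy has no direct precedent, so a step of uncertain size is expected, with a loss more likely than a gain; compound 4 is expected at a 6.3-fold higher number from compound 2 to compound 4 (0.80 log units; beyond the scatter). In this assay compound 4 is estimated at 15000 nM, between 3000 nM and 100000 nM.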

Compound 4, half-maximal effective concentration: 490 nM
The estimate for compound 4 lay 31-fold (1.49 log units) above the measured number; the whole stated range lies above it.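

In this assay, methoxy in place of tert-butyl gives a 4.9-fold lower number from compound 2 to compound 4 (0.69 log units; beyond the scatter), so this position gives a lower number with a group of fewer heavy atoms that also brings a hydrogen-bond acceptor. Together with the earlier step, the number now falls along cyclohexyl, tert-butyl and methoxy on this aromatic carbon, a trend resting on three compounds only, while compound 3, recorded as not active, offers no number to place in that order. Methoxy in place of cyclohexyl gives an at least 200-fold lower number from compound 1 to compound 4 (2.30 log units; beyond the scatter); the starting value is a limit, so this is only a lower bound of the step: the limit of > 100000 nM in this assay, at which 1 of the 4 values shown sits.

The compounds shown do not separate the drop in heavy atoms from the added hydrogen-bond acceptor, since both change together from tert-butyl to methoxy, and an ethyl group would bear on the first while a longer alkoxy chain would bear on the second. As far as these compounds go, whether the number keeps falling with a still smaller group on this carbon, such as a methyl group or a fluorine atom, or with an amine there, stays open.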